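The source may hold more compounds than are shown below. What is called first, only, known or untested is meant among the compounds shown, and "the series" means these compounds.

In a functional assay on HeLa cells (Homo sapiens) for cytotoxicity, read by MTT assay, with a stated time of 48 h (a higher number here means a weaker inhibitor, a lower number a stronger inhibitor), compound 1 (`COc1ccc(/C=C/c2cc(OC)c(OC)c(OC)c2-c2ccc(OC)cc2)cc1`) gives 19000 nM and compound 2 (`C=C(c1ccc(OC)cc1)c1cc(OC)c(OC)c(OC)c1-c1ccccc1`) gives 11000 nM, so these two numbers lie within the scatter of each other. Compound 3 (`C=C(c1ccc(OC)cc1)c1cc(OC)c(OC)c(OC)c1-c1ccc(Cl)cc1`) differs from compound 2 in one place, chloro in place of hydrogen on an aromatic carbon, para to a large group. Within the data shown here, no measured pair here isolates such a change, so only a slight lean towards a stronger inhibitor is expected, with no shift beyond the scatter. The expected step is a 1.4-fold lower number from compound 2 to compound 3 (0.14 log units; within the scatter). For compound 3, the estimated value is 8000 nM, with a range of 3000 nM to 20000 nM.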

Compound 3, half-maximal inhibitory concentration: 30000 nM
Estimate against measurement, compound 3: 3.8-fold (0.57 log units) below; measured number above the stated range.
By their numbers in this assay, from the lowest: compounds 2, 1 and 3 (each within the scatter of the next, the first and the last beyond it).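

In this assay, replacing phenyl with 4-chlorophenyl, para to a large group, produces a 2.7-fold higher number from compound 2 to compound 3 (0.44 log units; beyond the scatter), so this position is not indifferent to the change and the chloro compound is the weaker inhibitor. Among these compounds, this is the first single-place step available here, since the earlier compounds offered no such pair. No measurement shown accounts for the step.

On these data alone, whether fluoro or an amine at this same place would also weaken inhibition remains open. So does whether chloro would have the same effect on the core of compound 1.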